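Thiosemicarbazones on glioblastoma cells: configuration drawn, nothing else changed

The source may hold more compounds than are shown below. What is called first, only, known or untested is meant among the compounds shown, and "the series" means these compounds.

Measured so far:
compound 1 `C/C(=N/NC(=S)Nc1ccccc1I)c1ccccn1`: 8.09 nM
compound 2 `CC(=NNC(=S)Nc1ccccc1F)c1ccccn1`: 3.1 nM
compound 3 `CC(=NNC(=S)Nc1cccc(I)c1)c1ccccn1`: 61 nM

In a functional assay on T98G cells (Homo sapiens) for cytotoxicity, read by MTT assay, with a stated time of 48 h (a lower number here means a stronger inhibitor, a higher number a weaker inhibitor), compound 3 gives 61 nM, the highest number of the three. Compound 1, nearest to it, lies lower by a margin beyond the scatter, and compound 2 lies lower still, also beyond the scatter.

Compound 4 `C/C(=N\NC(=S)Nc1cccc(I)c1)c1ccccn1` is the next member. Relative to compound 3 it differs only as counted here: the two compounds have the same atoms and bonds; at least one stereo element is drawn with a configuration in one of them and without one in the other: 1 of 1 stereo elements differ; a double bond is drawn without a configuration in compound 3 and E in compound 4. The same atoms and bonds are present; the only distinction is that the double bond carries a drawn configuration in compound 4 and none in compound 3. Going by the values given here, no step between two measured compounds of this kind exists in the set.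

For compound 4 the expected step is no change at the digits printed from compound 3 to compound 4 (within the scatter), none beyond the scatter. Compound 4 is therefore estimated at 61 nM, within 25 nM to 150 nM, because compound 3 gives 61 nM.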

Compound 4, half-maximal inhibitory concentration: 61 nM
For compound 4 middle estimate and measured number coincide at the digits printed, and the stated range covers the measured number.
By their numbers in this assay, from the lowest: compound 2; then compound 1; then compounds 3 and 4 (each within the scatter of the next).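

In this assay, going by these compounds alone, the step is no change at the digits printed from compound 3 to compound 4 (within the scatter), the first step between two measured compounds that differ in one place. At this double bond, a drawn E configuration and no drawn configuration therefore read alike, so the drawing alone separates nothing here. The reading of the pair rests on one fact: the fact that one of compounds 3 and 4 is drawn with a defined configuration and the other without, at the place where they differ

Still open, on these data alone, is how a drawn Z configuration at this double bond would read in the same compound. Also open, as far as these compounds go, is what an amine or a carboxylic acid in place of the iodine would give.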